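Piperidin-1-yl replacement in the series

This account rests on a few compounds, and the source may have more. Where it says the series, first, only, none or still open, it means among the compounds named here.

Among the compounds with values here, only two compounds have numbers so far. In a physicochemical assay for solubility, read by HPLC, in phosphate buffer, at pH 6.5 (a lower number here means a less soluble compound, a higher number a more soluble compound), compound 1 (`COC(=O)C1=C(C)NC(c2nccs2)=NC1(C)c1ccc(Cl)cc1`) gives 14 ug/mL and compound 2 (`COC(=O)C1=C(CN2CCCCC2)NC(c2nccs2)=NC1(C)c1ccc(F)cc1`) gives 282 ug/mL as the higher of the two numbers, and the gap between them lies beyond the usual scatter. These two compounds differ in more than one place, so their gap cannot be tied to any single change.

Compound 3 (`COC(=O)C1=C(CN2CC3CC2CO3)NC(c2nccs2)=NC1(C)c1ccc(F)cc1`) departs from compound 2 in one place only (a group of 7 heavy atoms (5 carbon, 1 nitrogen, 1 oxygen; 2 five-membered non-aromatic rings with 1 hetero atom each) in place of a group of 6 heavy atoms (5 carbon, 1 nitrogen; one six-membered non-aromatic ring with 1 hetero atom), on a saturated chain carbon bound to a double-bonded ring carbon). The rest of the structure stays the same. Within the data shown here, no measured pair shows a change at this carbon, so the data give no direct guide to the size or direction of this step. The nearest anchor is compound 2 at 282 ug/mL in the same assay, and the estimate starts from that number. In this assay the expected result is a 1.4-fold lower number from compound 2 to compound 3 (0.15 log units; within the scatter) with a slight downward lean, which stays within the scatter. With so little to go on, the range is kept wide. Compound 3 is estimated at 200 ug/mL with a range from 60 ug/mL to 600 ug/mL expected to hold the measurement.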

Compound 3, solubility: 564 ug/mL
Compound 3: the middle estimate sits 2.8-fold (0.45 log units) below what was measured; the range from low to high includes it.
By their numbers in this assay, from the lowest: compound 1; then compounds 2 and 3 (each within the scatter of the next).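

Within the data shown here, this is the first step that can be tied to a single place, the saturated chain carbon bound to a double-bonded ring carbon, and in this assay it reads as a 2.0-fold higher number from compound 2 to compound 3 (0.30 log units; within the scatter). Piperidin-1-yl, with 6 heavy atoms and 1 hydrogen-bond acceptor, can therefore be exchanged at this carbon for the group with 2 five-membered non-aromatic rings with 1 hetero atom each, 7 heavy atoms and 2 hydrogen-bond acceptors, and the result stays within the scatter of compound 2. Nothing measured on these compounds offers an explanation for this result.

Among these compounds, the single step says nothing about the gap to compound 1, which differs from compound 2 in more than one place, so that gap remains unassigned to any one change. Going by these compounds, how a morpholin-4-yl group or an open-chain dimethylamino group on this same carbon would read in this assay remains open, as does whether this exchange would give a similar step on a different substitution of the shared core.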